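A few compounds are considered here, and "the series" means these few. Any claim that something is new, unique, unknown or untested is made for them only; others in the source may bear on it.

Working notes on the series, read in a functional assay on HepG2 cells (Homo sapiens) for cytotoxicity, read by MTT assay, with a stated time of 24 h; a higher number here means a weaker inhibitor, a lower number a stronger inhibitor. Compound 1 (`CN1C/C(=C\c2ccc(F)cc2)C(=O)/C(=C/c2cccc([N+](=O)[O-])c2)C1`) gives 9340 nM, and compound 2 (`CN1C/C(=C\c2cccc([N+](=O)[O-])c2)C(=O)/C(=C/c2ccc(Cl)cc2Cl)C1`) gives 4800 nM. Within the data shown here, the only measured step is a 1.9-fold lower number from compound 1 to compound 2 (0.29 log units; within the scatter), so compound 2 stands level with compound 1 on these numbers. Next comes compound 3 (`CN1C/C(=C\c2cccc(Br)c2)C(=O)/C(=C/c2cccc([N+](=O)[O-])c2)C1`), with the change (3-bromophenyl in place of 2,4-dichlorophenyl on a double-bonded chain carbon bound to a double-bonded ring carbon). The measured step bearing on this change swapped the group at the same place, 2,4-dichlorophenyl in place of 4-fluorophenyl. Among the measured compounds shown here, no compound measured so far carries 3-bromophenyl, so this rests on compound 1 and compound 2 alone. Going by a 1.9-fold lower number from compound 1 to compound 2 (0.29 log units; within the scatter) at that place, no step beyond the scatter is expected in this assay, and no firm direction. For compound 3 the estimated value is 6500 nM, with an expected range of 2800 nM to 15000 nM. The estimate means an expected 1.4-fold higher number from compound 2 to compound 3 (0.13 log units; within the scatter).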

Compound 3, half-maximal inhibitory concentration: 4890 nM
For compound 3 the middle estimate is 1.3-fold (0.12 log units) above the measured one; the range from low to high includes it.
By their numbers in this assay, from the lowest: compounds 2, 3 and 1 (each within the scatter of the next).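

In this assay, this position now carries three halogen-bearing phenyl groups, and no readable step separates them: a 1.0-fold higher number from compound 2 to compound 3 (0.01 log units; within the scatter) and a 1.9-fold lower number from compound 1 to compound 3 (0.28 log units; within the scatter). Among these compounds, with 3-bromophenyl as a second replacement for 4-fluorophenyl, the flat reading no longer rests on the single earlier pair, and the exchange between 2,4-dichlorophenyl and 3-bromophenyl also gives no step beyond the scatter. Nothing available gives a reason for this flat reading.

As far as these compounds go, whether any group at this place can move the number beyond the scatter stays open, since all three compounds keep a halogen-bearing phenyl there; an aminophenyl, a carboxyphenyl or a plain alkyl chain would test this. From the compounds shown here alone, it is also open whether the flat reading would hold with a different group on the other double-bonded chain carbon.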